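Swapping a phenyl for a pyridinyloxy group on the shared core

The source may report more compounds than this note shows. Statements on the series, on what has been measured and on what is new or still open speak of the compounds shown alone.

Of the compounds shown here, three sharing one core have been measured in an assay for inhibition of inositol hexakisphosphate kinase 3 (Homo sapiens), read by colorimetric assay, coupled enzyme assay and malachite green, with a stated time of 120 min, in the presence of a further agent that is not named here; on this read-out higher numbers stand for weaker inhibition and lower numbers for stronger inhibition. Compound 1 `Cc1cccc(-c2onc3ccc(C(=O)O)cc23)c1` carries a methyl group and gives 1410 nM. Compound 2 `O=C(O)c1ccc2noc(-c3cccc(NC(=O)C4CC4)c3)c2c1` carries a (cyclopropylcarbonyl)amino group in the same place and gives 2810 nM. Compound 3 `O=C(O)c1ccc2noc(-c3cccc(-c4ccccc4)c3)c2c1` carries a phenyl group there and gives 840 nM, the lowest of the three numbers; its gap to compound 1 lies within the scatter, as a 1.7-fold lower number from compound 1 to compound 3 (0.22 log units; within the scatter) shows, while a 3.3-fold lower number from compound 2 to compound 3 (0.52 log units; beyond the scatter) is a modest step beyond it.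

Compound 4 `O=C(O)c1ccc2noc(-c3cccc(Oc4ccccn4)c3)c2c1` has not yet been measured. It differs from compound 3 in one place: (pyridin-2-yl)oxy in place of phenyl on an aromatic carbon. Among the compounds with values here, two measured steps bear on this position. Exchanging methyl for phenyl gave a 1.7-fold lower number from compound 1 to compound 3 (0.22 log units; within the scatter), and exchanging (cyclopropylcarbonyl)amino for phenyl gave a 3.3-fold lower number from compound 2 to compound 3 (0.52 log units; beyond the scatter). Within the data shown here, a ring bearing a hetero atom joined through an oxygen has no direct precedent here, so the expectation is guided by the observation that all three groups at this position keep the number within a modest span. The estimate for compound 4 is therefore a 1.4-fold higher number from compound 3 to compound 4 (0.15 log units; within the scatter), a change expected to stay within or just at the edge of the scatter. In this assay compound 4 is expected to give about 1200 nM, with a likely range from 400 nM to 3600 nM.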

Compound 4, half-maximal inhibitory concentration: 10900 nM
Estimate against measurement, compound 4: 9.1-fold (0.96 log units) below; the measured number lies above the stated range.
By their numbers in this assay, from the lowest: compounds 3, 1 and 2 (each within the scatter of the next, the first and the last beyond it); then compound 4.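

In this assay, this position on the aromatic carbon proves far less forgiving than the first three compounds suggested, for (pyridin-2-yl)oxy in place of phenyl gives a 13-fold higher number from compound 3 to compound 4 (1.11 log units; beyond the scatter). The new group also stands apart from the two other groups, with a 3.9-fold higher number from compound 2 to compound 4 (0.59 log units; beyond the scatter) and a 7.7-fold higher number from compound 1 to compound 4 (0.89 log units; beyond the scatter), which makes compound 4 the weakest inhibitor of the four, beyond the scatter from each of the others. Nothing available here accounts for this loss.

The compounds shown leave open which part of the entering group matters, the oxygen link or the nitrogen in the ring: a phenoxy group would keep the link with a ring of carbon only, while a pyridin-2-yl group would keep the ring without the oxygen. They also leave open whether the loss belongs to this one attachment of the ring, as a (pyridin-3-yl)oxy or (pyridin-4-yl)oxy group at the same place would put the ring nitrogen elsewhere while keeping the oxygen link.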